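The compounds below may be only part of what the source reports. "The series", "measured", "known", "first", "only" and "open" are said of these compounds alone.

Measured so far in a functional assay on Hep 3B2 cells (Homo sapiens) for inhibition, read by sulforhodamine B assay, with a stated time of 72 h; on this read-out lower numbers stand for stronger inhibition and higher numbers for weaker inhibition:
- compound 1 `C[C@H](Nc1ncnc2[nH]cnc12)c1nn(-c2cccnc2)c2ccc(F)cc12`: 40100 nM
- compound 2 `Cc1ccc2c(c1)c([C@H](C)Nc1ncnc3[nH]cnc13)nn2-c1cccnc1`: > 40000 nM (a limit)
- compound 3 `C[C@H](Nc1ncnc2[nH]cnc12)c1nn(-c2cccc(F)c2)c2cc(F)ccc12`: > 40000 nM (a limit)

Compound 3 has no readable number, only a limit. The series as a whole stands at the limit of > 40000 nM in this assay, at which 2 of the 3 values shown sit, and compound 1 alone carries an actual number.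

The next change leads to compound 4 `C[C@H](Nc1ncnc2[nH]cnc12)c1nn(-c2cc(F)cc(F)c2)c2cc(F)ccc12`. The difference is fluoro in place of hydrogen on an aromatic carbon, meta to a fluoro group, turning 3-fluorophenyl into 3,5-difluorophenyl.

Among the compounds with values here, only one measured step is available, a step that the limit leaves unreadable from compound 1 to compound 2. It concerns methyl in place of fluoro on an aromatic carbon, a different change, and it gives no size to carry over. With no measured size to draw on, no step beyond the scatter is expected in this assay, in either direction. The expectation rests on compound 3, whose value of > 40000 nM is a limit, so compound 4 will most likely be reported as a limit too.

The expected change is a step that the limit leaves unreadable from compound 3 to compound 4. For compound 4 the estimate is 45000 nM, with an expected range of 25000 nM to 80000 nM.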

Compound 4, half-maximal inhibitory concentration: > 40000 nM
Compound 4: only a limit was reported (the forecaster's own chance of this, stated with the estimate: 80%); the middle value does not contradict the limit.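

In this assay compound 3 and compound 4 are both reported only as limits, so no step can be read for the change from 3-fluorophenyl to 3,5-difluorophenyl. The series remains largely at one limit: the limit of > 40000 nM in this assay, at which 3 of the 4 values shown sit.

The compounds shown leave open whether the added fluoro changes inhibition at all, in either direction.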